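The source may report more compounds than this note shows. Statements on the series, on what has been measured and on what is new or still open speak of the compounds shown alone.

Series notes, compounds 1 to 4.

Compound 2 `N#Cc1c(N2CCC(c3ccccc3)CC2)ccn(CCC2CC2)c1=O` and compound 1 `CC(C)CCn1ccc(N2CCC(c3ccccc3)CC2)c(C#N)c1=O` differ by isopropyl in place of cyclopropyl on a saturated chain carbon, two bonds along the chain from an aromatic nitrogen. In a functional assay on CHO cells for positive allosteric modulation of metabotropic glutamate receptor 2 (Homo sapiens), with a stated time of 30 min (a lower number here means a smaller maximal response, a higher number a larger maximal response), compound 2 gives 316% and compound 1 gives 268%; the step is a number 48 percentage points lower from compound 2 to compound 1 (beyond the scatter).

Compound 3 `O=c1c(Cl)c(N2CCC(c3ccccc3)CC2)ccn1CC1CC1` carries a different core; the difference between the core of compound 3 and that of compound 2 is not broken down here. In this assay compound 3 gives 259%, the lowest of the three numbers, within the scatter of compound 1 and beyond it from compound 2.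

Compound 4 `CC(C)Cn1ccc(N2CCC(c3ccccc3)CC2)c(Cl)c1=O` is not yet measured. It differs from compound 3 by isopropyl in place of cyclopropyl on a saturated chain carbon bound to an aromatic nitrogen, the same kind of change as from compound 2 to compound 1, though the place is not identical: there it sat two bonds along the chain from the aromatic nitrogen, here it is bound to the aromatic nitrogen. Among the compounds with values here, a step of similar direction is expected because a number 48 percentage points lower from compound 2 to compound 1 (beyond the scatter) is the single precedent, with a somewhat smaller size allowed for the changed core and place. For compound 4 the expected step in this assay is a number 39 percentage points lower from compound 3 to compound 4 (beyond the scatter). Compound 4 is therefore estimated at 220%, with a likely range from 170% to 270%.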

Compound 4, largest response reached (Emax), in percent of the reference or control that the assay uses: 260%
Compound 4: middle estimate off by 40 percentage points, on the low side; the measured number falls inside the stated range.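

In this assay isopropyl in place of cyclopropyl gives a number 1 percentage points higher from compound 3 to compound 4 (within the scatter) and so shows no loss on this core. Within the data shown here, this does not show what sets the outcome: only two pairs are available, and they differ in core as well as in place, with the change bound to the aromatic nitrogen here and two bonds along the chain from it in the earlier pair. What can be said is that the change does not carry over with a fixed size from one core to the other: the same change on two cores in this assay, a number 48 percentage points lower (beyond the scatter) from compound 2 to compound 1 and a number 1 percentage points higher (within the scatter) from compound 3 to compound 4, 49 percentage points apart, beyond the scatter of two such steps

Still open, on these data alone, is whether core or place governs the step, which would need the same chain on both cores. Also open, as far as these compounds go, is how a longer chain or a cyclobutyl group would behave on either core.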